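A few compounds are considered here, and "the series" means these few. Any claim that something is new, unique, unknown or untested is made for them only; others in the source may bear on it.

Measured compounds:
Compound 1, `COc1cc(Cl)cc(-c2nn(-c3cccc(NC(=O)c4ccc(Cl)c(Cl)c4)c3)cc2-c2ccncc2)c1`: 68.9%
Compound 2, `O=C(Nc1cccc(-n2cc(-c3ccncc3)c(-c3cc(O)cc(Cl)c3)n2)c1)Nc1ccc(Cl)c(C(F)(F)F)c1`: -16.8%

In a functional assay on M14 cells (Homo sapiens) for inhibition, read by sulforhodamine B assay, with a stated time of 48 h, tested at 10 uM (a lower number here means a stronger effect, a higher number a weaker effect of the compound at the concentration tested), compound 1 gives 68.9%. In this assay, among the measured compounds shown here, compound 2 gives -16.8%, which is the lowest of the two numbers known so far; the nearest number, that of compound 1, lies well above it, beyond the usual scatter. For the measured compounds named here, the two compounds differ in more than one place, so their two values show only that compound 2 acts far more strongly at the tested concentration, and no single change can be read from the pair.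

Compound 3, `COc1cc(Cl)cc(-c2nn(-c3cccc(NC(=O)Nc4ccc(Cl)c(C(F)(F)F)c4)c3)cc2-c2ccncc2)c1`, has not yet been measured in this assay. It is compound 2 with one alteration: methyl in place of hydrogen on an oxygen on an aromatic ring. Going by the values given here, no measured pair shows this change alone, so the expectation rests on compound 2 and on the fact that compound 1, the only other compound carrying a methoxy group, gives 68.9%. For compound 3 the expected step in this assay is a number 26.8 percentage points higher from compound 2 to compound 3 (beyond the scatter), a modest weakening, though possibly none beyond the scatter. Compound 3 is estimated to give 10%, within a range from -30% to 55%.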

Compound 3, a percentage reported as activity, at one concentration (the size of the read-out at that concentration, not a potency): 3.99%
Compound 3: the middle estimate sits 6 percentage points above what was measured; the measured number falls inside the stated range.
By their numbers in this assay, from the lowest: compound 2; then compound 3; then compound 1.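

The hydrogen on the oxygen of the 3-chloro-5-hydroxyphenyl group is not indispensable in this assay: hydroxy to methoxy gives a number 20.8 percentage points higher from compound 2 to compound 3 (beyond the scatter), a modest loss of effect at the tested concentration. Compound 1 also carries the methoxy group, but that group alone does not account for its much higher number, since placing (4-chloro-3-(trifluoromethyl)phenyl)amino instead of 3,4-dichlorophenyl on the carbonyl carbon gives a number 64.9 percentage points lower from compound 1 to compound 3 (beyond the scatter), a large step that far outweighs the methoxy change among these compounds. Nothing available explains either step, so the reason for these differences remains unknown.

Among the compounds shown here, it remains open whether the hydroxy to methoxy step would be of similar size with 3,4-dichlorophenyl on the carbonyl carbon, as the only measured pair for this change carries the (4-chloro-3-(trifluoromethyl)phenyl)amino group. The compounds shown also leave open how an ethoxy group, a longer alkoxy chain or an amine would compare at this same place on the aromatic ring.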